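A shorter alkenyl chain replacing a nitrile-bearing branched chain

The source may report more compounds than this note shows. Statements on the series, on what has been measured and on what is new or still open speak of the compounds shown alone.

Measured compounds:
compound 1, `CC(C)(C)C(NC(=O)c1ccc(Cl)cc1)N/C(=N/c1cccnc1)NS(N)(=O)=O`, < 100000 nM
compound 2, `CCC(CC)(CCC#N)C(NC(=O)c1ccc(Cl)cc1)N/C(=N/c1cccnc1)NC#N`, 5010 nM

In a functional assay with sulfonylurea receptor 2, Kir6.2 (Homo sapiens) as the target (on this read-out higher numbers stand for an effect only at larger amounts of compound and lower numbers for an effect already at smaller amounts), compound 1 reaches only a limit of the assay, < 100000 nM. That is the limit of < 100000 nM in this assay, at which 1 of the 2 values shown sits. Among the compounds with values here, compound 2 gives 5010 nM in this assay and is therefore the only compound with a real number here. Compound 3, `C=CCC(C)(C)C(NC(=O)c1ccc(Cl)cc1)N/C(=N/c1cccnc1)NC#N`, is not yet measured and differs from compound 2 in one place: 1,1-dimethylbut-3-en-1-yl in place of 1-(2-cyanoethyl)-1-ethylpropyl on a saturated chain carbon bound to an amide-type nitrogen and an amine nitrogen. Within the data shown here, no measured pair shows the effect of such a swap, so a step beyond the usual scatter in either direction is possible. The estimate for compound 3 is 8000 nM, between 2000 nM and 32000 nM, an expected step of a 1.6-fold higher number from compound 2 to compound 3 (0.20 log units; within the scatter).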

Compound 3, half-maximal effective concentration: 20000 nM
Compound 3: the middle estimate sits 2.5-fold (0.40 log units) below what was measured; the measured number falls inside the stated range.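

In this assay, putting 1,1-dimethylbut-3-en-1-yl in place of 1-(2-cyanoethyl)-1-ethylpropyl gives a 4.0-fold higher number from compound 2 to compound 3 (0.60 log units; beyond the scatter), so the read-out responds to the group at this position. This single swap removes the nitrile, shortens the group and adds a double bond all at once, so their separate contributions cannot be told apart. Nothing measured here explains the step.

Still open, going by these compounds, is how a chain carrying a nitrile on the same 1,1-dimethyl branch would read. On these data alone, an amine or a carboxylic acid at the end of that chain is equally open.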